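Sulfonamide Variation on a Benzoxazole Core: Cytotoxicity Outlook

The source may report more compounds than this note shows. Statements on the series, on what has been measured and on what is new or still open speak of the compounds shown alone.

Compound 1 `O=S(=O)(Nc1ccc(-c2nc3ccccc3o2)cc1)c1ccccc1C(F)(F)F` gives > 100000 nM in an ADME assay on HEK293 cells (Homo sapiens) for cytotoxicity, read by resazurin assay, with a stated time of 48 h (on this read-out higher numbers stand for lower toxicity in this test and lower numbers for higher toxicity in this test), a limit of the measurement.
Compound 2 `COc1ccc(Cl)cc1S(=O)(=O)Nc1ccc(-c2nc3ccccc3o2)cc1` gives 75000 nM in this assay.
Compound 3 `CS(=O)(=O)Nc1ccc2oc(-c3ccccc3)nc2c1` gives > 100000 nM in this assay, again a limit rather than a number.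

On these data alone, compound 3 thus stands at the limit of > 100000 nM in this assay, at which 2 of the 3 values shown sit, so its exact value is unknown. Compound 4 `O=S(=O)(Nc1ccc2oc(-c3ccccc3)nc2c1)c1ccc(Cl)s1` differs from compound 3 by 5-chlorothiophen-2-yl in place of methyl on a sulfonyl sulfur. Among the measured compounds shown here, no measured pair shows this change, so the direction is open; the only aryl sulfonamide with a number, compound 2, sits near the limit, and compound 1 reaches it. Compound 4 is expected to show a step of an at least 1.2-fold lower number from compound 3 to compound 4 (0.09 log units; that floor lies within the scatter), within the usual scatter. Compound 4 is estimated at 80000 nM, in the range 30000 nM to 200000 nM.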

Compound 4, half-maximal cytotoxic concentration: > 100000 nM
Compound 4: only a limit was reported; the forecaster's own chance of this, stated with the estimate: 50%; middle value at least 1.2-fold (0.09 log units) away from the limit.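

Among the compounds shown here, compound 3 and compound 4 both sit at a limit, so no step between them can be read in this assay: the limit of > 100000 nM in this assay, at which 3 of the 4 values shown sit. The compounds shown leave open the exact value of each and whether 5-chlorothiophen-2-yl in place of methyl changes the read-out at all.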